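Cytotoxicity notes on the oxadiazole-quinoline series

The source may hold more compounds than are shown below. What is called first, only, known or untested is meant among the compounds shown, and "the series" means these compounds.

Measured so far in a functional assay on RD cells (Homo sapiens) for inhibition, read by luminescence and ATP content, with a stated time of 72 h; a lower number here means that less compound is tolerated, a higher number that more compound is tolerated:
compound 1 `Cc1ccc(-c2ccc3ncc(-c4noc(C(F)(F)F)n4)cc3c2)cc1` gives > 22200 nM, a limit.
compound 2 `Fc1ccc(-c2ccc3ncc(-c4noc(C(F)(F)F)n4)cc3c2)cc1` gives > 7400 nM, a limit.
compound 3 `CN(C)c1ccc(-c2ccc3ncc(-c4noc(C(F)(F)F)n4)cc3c2)cc1` gives > 22200 nM, a limit.

Compound 1 stands only at a limit in this assay, as do compound 2 and compound 3. The steps a step that the two limits leave unreadable from compound 1 to compound 2, a step that the two limits leave unreadable from compound 1 to compound 3 and a step that the two limits leave unreadable from compound 2 to compound 3 are therefore not readable in size. Compound 4 `CCc1nc(-c2cnc3ccc(-c4ccc(C)cc4)cc3c2)no1` differs from compound 1 by ethyl in place of trifluoromethyl on an aromatic carbon. Going by the values given here, none of the measured steps touches the place of the trifluoromethyl; each concerns the substituent on the phenyl and each is unreadable. So no step beyond the scatter is expected in this assay, and the value is expected to remain a limit, in line with the limit of > 22200 nM in this assay, at which 2 of the 3 values shown sit. Compound 4 is estimated at 30000 nM, range 10000 nM to 100000 nM, which means the expected step that the limit leaves unreadable from compound 1 to compound 4.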

Compound 4, half-maximal cytotoxic concentration: > 7400 nM
Compound 4 was reported as a limit; the forecaster's own chance of this, stated with the estimate: 80%; the middle value does not contradict the limit.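

In this assay compound 1 and compound 4 both stand only at limits, so the step between them cannot be read. The compounds shown leave open at what concentration any of them becomes cytotoxic, and whether ethyl and trifluoromethyl differ at all in that place.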